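Removing one hydroxyethoxy group: expected solubility of compound 4

The compounds below may be only part of what the source reports. "The series", "measured", "known", "first", "only" and "open" are said of these compounds alone.

Compound 1 `COc1cc(/C=C/C(=O)NCCn2c(C)cc3ccccc32)cc(OC)c1`, compound 2 `COc1cc(/C=C/C(=O)NCCn2c(C)cc3ccccc32)cc(OC)c1OCCO` and compound 3 `Cc1cc2ccccc2n1CCNC(=O)/C=C/c1ccc(OCCO)c(OCCO)c1` have been measured in a physicochemical assay for solubility, read by nephelometry, in phosphate buffer, at pH 7.4; on this read-out lower numbers stand for lower solubility and higher numbers for higher solubility. In this assay compound 2 gives 66000 nM, and compound 3 gives 153000 nM. For compound 1 this assay reports only a limit, < 25000 nM. The change from compound 2 to compound 1 is hydrogen in place of 2-hydroxyethoxy on an aromatic carbon; it brought an at least 2.6-fold lower number from compound 2 to compound 1 (0.42 log units; beyond the scatter). The difference between the cores of compound 2 and compound 3 is not broken down here. Compound 4 `Cc1cc2ccccc2n1CCNC(=O)/C=C/c1ccc(OCCO)cc1` is not yet measured; it differs from compound 3 by hydrogen in place of 2-hydroxyethoxy on an aromatic carbon, the same kind of change, though here the place is ortho to a 2-hydroxyethoxy group and meta to a large group rather than ortho to two methoxy groups and para to a large group. Beside the earlier step, a drop of similar size is expected, a 3.1-fold lower number from compound 3 to compound 4 (0.49 log units; beyond the scatter), resting on compound 2 and compound 1 with an at least 2.6-fold lower number from compound 2 to compound 1 (0.42 log units; beyond the scatter). Compound 4 is therefore estimated at 50000 nM, between 20000 nM and 110000 nM.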

Compound 4, solubility: 68000 nM
The estimate for compound 4 lay 1.4-fold (0.13 log units) below the measured number; the measured number falls inside the stated range.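

In this assay, hydrogen in place of 2-hydroxyethoxy on an aromatic carbon gave a 2.3-fold lower number from compound 3 to compound 4 (0.35 log units; beyond the scatter), and the same kind of change on the other core gave an at least 2.6-fold lower number from compound 2 to compound 1 (0.42 log units; beyond the scatter), so the direction held across these two cores. Compound 1 is reported only as a limit, < 25000 nM. The size of the earlier step therefore cannot be fixed, and the two steps cannot be compared in size: the limit of < 25000 nM in this assay, at which 1 of the 4 values shown sits.

The compounds shown leave open whether an amine, a carboxylic acid or a longer chain in place of 2-hydroxyethoxy would give numbers like those of compound 3. Core and place also change together between the two steps, and nothing here separates them.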